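Thiophen-3-yl for furan-2-yl at the assay limit

The source may report more compounds than this note shows. Statements on the series, on what has been measured and on what is new or still open speak of the compounds shown alone.

- Compound 1 `Cc1nc(N)c2c(-c3cccs3)cn([C@@H]3O[C@H](CO)[C@@H](O)[C@H]3O)c2n1`: > 100000 nM
- Compound 2 `Nc1nc2c(c(-c3ccco3)cn2[C@@H]2O[C@H](CO)[C@@H](O)[C@H]2O)c(=O)[nH]1`: > 100000 nM

In an ADME assay on BJ cells (Homo sapiens), read by MTT assay, with a stated time of 72 h (on this read-out higher numbers stand for weaker inhibition and lower numbers for stronger inhibition), compound 2 gives > 100000 nM, which is a limit of the assay and not a number. For the measured compounds named here, the same ceiling holds across the series so far: the limit of > 100000 nM in this assay, at which 2 of the 2 values shown sit. Compound 3 `Nc1nc2c(c(-c3ccsc3)cn2[C@@H]2O[C@H](CO)[C@@H](O)[C@H]2O)c(=O)[nH]1` carries thiophen-3-yl in place of furan-2-yl on an aromatic carbon of the shared core: thiophen-3-yl in place of furan-2-yl on an aromatic carbon. Going by the values given here, no measured step covers this exchange. The expected change a number no higher from compound 2 to compound 3 (the limit leaves the size open) lies within the scatter in this assay, with no direction foreseen. For compound 3 the estimated value is 100000 nM, with an expected range of 30000 nM to 100000 nM.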

Compound 3, half-maximal inhibitory concentration: > 100000 nM
Compound 3: no number, only a limit; the forecaster's own chance of this, stated with the estimate: 80%; the middle value lies on the limit itself.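

The step between compound 2 and compound 3 cannot be read, because both values are limits and not numbers: the limit of > 100000 nM in this assay, at which 3 of the 3 values shown sit.

The compounds shown leave open how thiophen-3-yl and furan-2-yl compare, and whether any change on the shared core gives a number rather than a limit.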